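Heteroaryl amide changes on a shared core

The compounds below may be only part of what the source reports. "The series", "measured", "known", "first", "only" and "open" are said of these compounds alone.

Measured compounds:
Compound 1 `CCCn1c(NC(=O)c2nccc3ccccc23)nc2cc(C(N)=O)cc(OC)c21`: in an assay for activation of interferon regulatory factor 3 (Homo sapiens), read by a luciferase reporter, with a stated time of 20 h (a lower number here means that less compound is needed, a higher number that more compound is needed for the effect), compound 1 gives > 100000 nM, a limit of the assay.
Compound 2 `CCCn1c(NC(=O)c2ccccn2)nc2cc(C(N)=O)cc(OC)c21`: in this assay compound 2 gives > 100000 nM, also a limit.
Compound 3 `CCCn1c(NC(=O)c2ccnn2CC)nc2cc(C(N)=O)cc(OC)c21`: in this assay compound 3 gives > 100000 nM, again a limit.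

Compound 3 stands where every value shown stands: at the limit of > 100000 nM in this assay, at which 3 of the 3 values shown sit. Nothing in this assay separates it from compound 1 or compound 2. The steps among the measured compounds are a step that the two limits leave unreadable from compound 1 to compound 2, a step that the two limits leave unreadable from compound 1 to compound 3 and a step that the two limits leave unreadable from compound 2 to compound 3; all three are unreadable because both ends of each sit at a limit.

Compound 4 `CCCn1c(NC(=O)c2ccnn2C)nc2cc(C(N)=O)cc(OC)c21` differs from compound 3 by hydrogen in place of methyl on a saturated chain carbon bound to an aromatic nitrogen. Among the measured compounds shown here, none of the measured steps touches this saturated chain on the pyrazole nitrogen, so no step bears on it directly. What bears on it is the ground: every change of the heteroaryl group on the carbonyl carbon, large or small, has left the value at the limit, and a change of one carbon on the side chain is expected to do the same. The step of a number no higher from compound 3 to compound 4 (the limit leaves the size open) is therefore expected to be none beyond the scatter, with the result most likely again a limit. Compound 4 is estimated at 100000 nM, within 50000 nM to 300000 nM.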

Compound 4, half-maximal effective concentration: > 100000 nM
Compound 4 was reported as a limit (the forecaster's own chance of this, stated with the estimate: 85%); the middle value lies on the limit itself.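

In this assay compound 4 gives > 100000 nM, a limit of the assay. No step joining compound 4 to compound 1, compound 2 or compound 3 can be read, since both ends of each sit at a limit: the limit of > 100000 nM in this assay, at which 4 of the 4 values shown sit.

The compounds shown leave open how these heteroaryl amides rank and whether any change on the shared core gives a measurable value.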